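The source may hold more compounds than are shown below. What is called first, only, known or untested is meant among the compounds shown, and "the series" means these compounds.

Measured so far:
- compound 1 `CCCCc1nc(=O)c(S(=O)(=O)c2ccc(-c3cccnc3)cc2)c(O)n1-c1c(OC)cccc1OC` gives 57% in an ADME assay on microsomes from liver (Mus musculus) for metabolic stability, using NADPH, with a stated time of 10 min; on this read-out higher numbers stand for a more stable compound and lower numbers for a less stable compound
- compound 2 `CCCCc1[nH]c(=O)c(S(=O)(=O)c2ccc(-n3ccccc3=O)cc2)c(O)c1-c1c(OC)cccc1OC` gives 75% in this assay

Of the two, compound 1 (57%) holds the lower number, and compound 2 (75%) stands higher by more than the usual scatter. Among the measured compounds shown here, no measured pair differs in one place only, so the series offers no measured single change to calibrate the next step.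

The next compound is compound 3 `CCCCc1nc(=O)c(S(=O)(=O)c2ccc(C3CC3)cc2)c(O)n1-c1c(OC)cccc1OC`, which departs from compound 1 in one place: cyclopropyl in place of pyridin-3-yl on an aromatic carbon and, in words, cyclopropyl in place of pyridin-3-yl on an aromatic carbon, para to a large group. For the measured compounds named here, nothing measured so far shows how this exchange behaves, so the expectation is anchored on compound 1 (57%) and the range is kept wide. In this assay the estimated a number 3 percentage points lower from compound 1 to compound 3 (within the scatter) is expected to stay within the scatter, with no firm direction. The estimate for compound 3 is 54%, expected to lie between 30% and 78%.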

Compound 3, percent of the compound remaining: 93%
Compound 3: middle estimate off by 39 percentage points, on the low side; measured number above the stated range.
By their numbers in this assay, from the lowest: compound 1; then compound 2; then compound 3.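

In this assay, replacing pyridin-3-yl with cyclopropyl on an aromatic carbon, para to a large group, gives a number 36 percentage points higher from compound 1 to compound 3 (beyond the scatter). This first measured single change in the series shows that the group at this position can strongly shift the percent of compound remaining, and that the 4-cyclopropylphenyl form stands well above the 4-(pyridin-3-yl)phenyl form on the core of compound 1. The exchange replaces a six-membered aromatic ring with 1 hetero atom by a three-membered non-aromatic ring of carbon only, and nothing available assigns the step to any one of these differences.

Going by these compounds, it remains open whether the gain comes from the arrival of cyclopropyl or the departure of pyridin-3-yl, and a phenyl, an isopropyl, a morpholine or a carboxylic acid at the same place would help separate ring size, ring type and the ring nitrogen. On these data alone, it also remains open whether the same exchange carries over to the core of compound 2, where the 1-pyridin-2-one group sits at this position.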